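This account rests on a few compounds, and the source may have more. Where it says the series, first, only, none or still open, it means among the compounds named here.

Three compounds have so far been run in a functional assay on MGC-803 cells (Homo sapiens) for inhibition, read by MTT assay, with a stated time of 48 h; on this read-out lower numbers stand for stronger inhibition and higher numbers for weaker inhibition. Among the measured compounds shown here, compound 1 `COc1ccc(CNc2cc(OC)c(OC)c(OC)c2)cc1[N+](=O)[O-]` gives 19400 nM, and compound 2 `COc1ccc(CNc2cc(OC)c(OC)c(OC)c2)cc1Br` gives 29400 nM; the single one-point step between them, a 1.5-fold higher number from compound 1 to compound 2 (0.18 log units; within the scatter), stays within the scatter. Compound 3 `C/C=C/C(=O)N(Cc1ccc(OC)c(N)c1)c1cc(OC)c(OC)c(OC)c1` gives 150 nM, the lowest of the three numbers and far beyond the scatter from both others. Compound 4 `C/C=C/C(=O)N(Cc1ccc(OC)c(O)c1)c1cc(OC)c(OC)c(OC)c1` differs from compound 3 by hydroxy in place of amino on an aromatic carbon. For the measured compounds named here, no measured step bears directly on this exchange; the only step known is a different exchange on the core of compound 1, and it was small. The step is therefore expected to be modest, estimated as a 1.7-fold higher number from compound 3 to compound 4 (0.22 log units; within the scatter). Compound 4 is expected to give about 250 nM, within 80 nM to 800 nM.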

Compound 4, half-maximal inhibitory concentration: 27 nM
For compound 4 the middle estimate is 9.3-fold (0.97 log units) above the measured one, outside the stated range (below it).
By their numbers in this assay, from the lowest: compound 4; then compound 3; then compounds 1 and 2 (each within the scatter of the next).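

In this assay the change from 3-amino-4-methoxyphenyl to 3-hydroxy-4-methoxyphenyl gives a 5.6-fold lower number from compound 3 to compound 4 (0.74 log units; beyond the scatter) and so lies beyond the scatter, showing that this position, ortho to a methoxy group, distinguishes hydroxy from amino even though the two match in heavy-atom, donor and acceptor counts. Among the compounds shown here, the only earlier exchange at this position, bromo for nitro on the core of compound 1, stayed within the scatter. No evidence at hand accounts for the difference. As far as these compounds go, whether a methyl group, a fluorine atom or an ethoxy group here would hold or lower the number remains open, as does whether hydroxy for amino would act alike on the core of compound 1.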